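Chloro to cyclopropyl on the aryl ring of compound 2

A few compounds are considered here, and "the series" means these few. Any claim that something is new, unique, unknown or untested is made for them only; others in the source may bear on it.

Measured compounds:
compound 1 `NC(=O)[C@@H]1CCN1Cc1ccc(OCc2cccc(F)c2)cc1Cl`, 35 nM
compound 2 `C[C@H](NCc1ccc(OCc2cccc(F)c2)cc1Cl)C(N)=O`, 28 nM
compound 3 `C#CCN(Cc1ccc(OCc2cccc(F)c2)cc1Cl)[C@@H](C)C(N)=O`, 68 nM

In an assay on Sf9 cells for inhibition of Amine oxidase [flavin-containing] B (Homo sapiens), with stated times of 15 min and 60 min (a lower number here means a stronger inhibitor, a higher number a weaker inhibitor), compound 2 gives 28 nM, the lowest of the three numbers; compound 1 sits nearest, with the step of a 1.3-fold lower number from compound 1 to compound 2 (0.10 log units; within the scatter) within the scatter, so compound 1 and compound 2 are not separated. The step of a 2.4-fold higher number from compound 2 to compound 3 (0.39 log units; beyond the scatter) is beyond the scatter and modest in size.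

Compound 4 `C[C@H](NCc1ccc(OCc2cccc(F)c2)cc1C1CC1)C(N)=O` differs from compound 2 by cyclopropyl in place of chloro on an aromatic carbon. Neither measured step touches this position: the step from compound 1 to compound 2 changes the amine side and the step from compound 2 to compound 3 adds propargyl on the amine nitrogen. No measured change on the aryl ring exists in this set, so the direction of the step cannot be read from the data. Given the two measured steps both stayed modest, compound 4 is expected to stay near compound 2, with a 1.6-fold higher number from compound 2 to compound 4 (0.21 log units; within the scatter) as the expected step. For compound 4 the estimate is 45 nM, with a range from 15 nM to 140 nM.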

Compound 4, half-maximal inhibitory concentration: 1660 nM
The estimate for compound 4 lay 37-fold (1.57 log units) below the measured number; the measured number lies above the stated range.
By their numbers in this assay, from the lowest: compounds 2, 1 and 3 (each within the scatter of the next, the first and the last beyond it); then compound 4.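

In this assay, chloro to cyclopropyl on the aromatic carbon ortho to the ((1-carbamoylethyl)amino)methyl group gives a 59-fold higher number from compound 2 to compound 4 (1.77 log units; beyond the scatter), so this one aryl position moves the number far more than either amine-side change, a 1.3-fold lower number from compound 1 to compound 2 (0.10 log units; within the scatter) and a 2.4-fold higher number from compound 2 to compound 3 (0.39 log units; beyond the scatter). The swap replaces 1 heavy atom with 3 and adds a three-membered ring, while the counts of hydrogen-bond donors and acceptors and the net charge stay the same on both groups. Nothing at hand ties the large step to any property of either group.

The compounds shown leave open whether the step reflects losing chloro or gaining cyclopropyl, and a methyl, a bromine or a fluorine at this position would help separate the two. Also open, as far as these compounds go, is whether the same step holds with the 2-carbamoylazetidin-1-yl or propargyl amine variants.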